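This account rests on a few compounds, and the source may have more. Where it says the series, first, only, none or still open, it means among the compounds named here.

Measured so far:
compound 1 `O=S(=O)(NC1CCN(S(=O)(=O)c2ccccc2)CC1)c1cc(S(=O)(=O)c2ccccc2)ccc1C(F)(F)F`; in an assay on isolated protein for displacement of a labelled ligand from secreted frizzled-related protein 1 (Homo sapiens), read by fluorescence polarization, with a stated time of 30 min (on this read-out higher numbers stand for weaker inhibition and lower numbers for stronger inhibition), compound 1 gives 130 nM
compound 2 `N#Cc1cccc(S(=O)(=O)N2CCC(NS(=O)(=O)c3cc(S(=O)(=O)c4ccccc4)ccc3C(F)(F)F)CC2)c1`; in this assay compound 2 gives 90 nM

Compound 2 holds the lowest of the two numbers, but its step to compound 1 is within the scatter: a 1.4-fold lower number from compound 1 to compound 2 (0.16 log units; within the scatter). On these numbers the two compounds cannot be told apart.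

Compound 3 `O=S(=O)(NC1CCN(S(=O)(=O)c2cccc(-c3nnn[nH]3)c2)CC1)c1cc(S(=O)(=O)c2ccccc2)ccc1C(F)(F)F` keeps the shared core and the sulfonyl-piperidine sulfonamide of compound 2 and changes only the substituent on the phenyl attached to the piperidine sulfonyl group: 1H-tetrazol-5-yl in place of cyano on an aromatic carbon.

Among the measured compounds shown here, the only measured step that bears on this position is the one from compound 1 to compound 2, where the cyano group entered, and that step was within the scatter. For the measured compounds named here, no measured step covers a tetrazole at this place or any other ring at the same position, so there is nothing to suggest a direction for the change from cyano to 1H-tetrazol-5-yl. Going by the values given here, since the one known step at this site, a 1.4-fold lower number from compound 1 to compound 2 (0.16 log units; within the scatter), was small, the working expectation is a step of a 1.3-fold higher number from compound 2 to compound 3 (0.12 log units; within the scatter) in this assay, that is, nothing beyond the scatter, with a wide margin to cover the larger group.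

Compound 3 is therefore estimated at 120 nM, with a range from 40 nM to 400 nM.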

Compound 3, half-maximal inhibitory concentration in the secreted frizzled-related protein 1 assay: 30 nM
Compound 3: middle estimate off by 4.0-fold (0.60 log units), on the high side; measured number below the stated range.
By their numbers in the secreted frizzled-related protein 1 assay, from the lowest: compound 3; then compounds 2 and 1 (each within the scatter of the next).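

In the secreted frizzled-related protein 1 assay this position proved able to respond to the group placed on it. The entry of cyano gave only a 1.4-fold lower number from compound 1 to compound 2 (0.16 log units; within the scatter), whereas 1H-tetrazol-5-yl in place of cyano gives a 3.0-fold lower number from compound 2 to compound 3 (0.48 log units; beyond the scatter), and in place of hydrogen gives a 4.3-fold lower number from compound 1 to compound 3 (0.64 log units; beyond the scatter). Among the compounds shown here, the gain in inhibition also comes with a shift the earlier compounds could not show, a move in the same favourable direction in a physicochemical assay for solubility (on this read-out higher numbers stand for higher solubility and lower numbers for lower solubility), where compound 2 gives 6300 nM and compound 3 gives 100000 nM as measured: the measured solubility of compound 2, 6300 nM, and of compound 3, 100000 nM, a 16-fold higher number (1.20 log units; beyond the scatter). On this one pair, then, the change from cyano to 1H-tetrazol-5-yl improves both read-outs, so neither has to be traded against the other at this place.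

The compounds shown leave open whether the step in the secreted frizzled-related protein 1 assay follows from the five-membered aromatic ring itself or from the hydrogen-bond donor that enters with it, a question that a carboxylic acid or a tetrazole carrying a methyl group on its ring nitrogen at the same place would help to separate. Also open, as far as these compounds go, is whether 1H-tetrazol-5-yl would give a similar step on another carbon of this aromatic ring.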